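This account rests on a few compounds, and the source may have more. Where it says the series, first, only, none or still open, it means among the compounds named here.

Compound 1 `O=C(Nc1ccc(Cl)c(-c2nnc3c(Cl)cccn23)c1)c1ccccn1` gives > 100000 nM in a functional assay on T47D cells (Homo sapiens) for antiproliferative activity, read by MTT assay, with a stated time of 72 h; a lower number here means a stronger inhibitor, a higher number a weaker inhibitor.
Compound 2 `Cc1cc(Cl)ccc1C(=O)Nc1ccc(Cl)c(-c2nnc3c(Cl)cccn23)c1` gives > 100000 nM in this assay.

Neither of these is a measured number. For compound 1 the value > 100000 nM is a limit of this assay. For compound 2 the value > 100000 nM is likewise a limit. Going by the values given here, the only measured step, a step that the two limits leave unreadable from compound 1 to compound 2, stays unreadable because the limit of > 100000 nM in this assay, at which 2 of the 2 values shown sit, holds both of its ends. Compound 2 therefore stands only at a limit, with no number of its own to build on.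

Compound 3 `O=C(Nc1ccc(Cl)c(-c2nnc3c(Cl)cccn23)c1)c1ccc(Cl)cc1Cl` differs from compound 2 by chloro in place of methyl on an aromatic carbon. Among the compounds with values here, no measured step bears on this change, and the one step recorded has no readable size. The expectation in this assay is therefore no change beyond the scatter, with compound 3 most likely staying at the same limit. The estimated step is a number no higher from compound 2 to compound 3 (the limit leaves the size open). For compound 3 the expected value is 100000 nM, in a range from 30000 nM to 300000 nM.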

Compound 3, half-maximal inhibitory concentration: > 100000 nM
Compound 3 gave a limit, no number; the forecaster's own chance of this, stated with the estimate: 85%; the middle value lies on the limit itself.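

Going by these compounds alone, compound 1, compound 2 and compound 3 all sit at a limit rather than at a measured number, so no step among them can be read: the limit of > 100000 nM in this assay, at which 3 of the 3 values shown sit.

The compounds shown leave open how far apart they truly lie in this assay, and which change to the shared core would bring a measurable value.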